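The compounds below may be only part of what the source reports. "The series", "measured", "known", "first", "only" and "open" are said of these compounds alone.

Of the compounds shown here, three built on one shared core have been tested in an assay on isolated protein for inhibition of DNA topoisomerase 1 (Homo sapiens), with a stated time of 30 min, tested at 20 uM; a higher number here means a stronger effect of the compound at the concentration tested, a lower number a weaker effect. Compound 1 `Oc1cccc(-c2cc(-c3cccs3)cc(-c3cccc(O)c3)n2)c1` gives 0%, and compound 2 `Oc1cccc(-c2cc(-c3ccsc3)cc(-c3cccc(O)c3)n2)c1` gives 4.5%. The step of a number 4.5 percentage points higher from compound 1 to compound 2 (within the scatter) puts thiophen-3-yl in place of thiophen-2-yl on an aromatic carbon. Compound 3 `Oc1cccc(-c2cc(-c3ccco3)cc(-c3ccccc3O)n2)c1` gives 0%, level with compound 1 and together with it the lowest of the three numbers, while compound 2 lies only a small distance away within the scatter. Compound 4 `Oc1cccc(-c2cc(-c3ccco3)cc(-c3cccc(O)c3)n2)c1` differs from compound 3 by 3-hydroxyphenyl in place of 2-hydroxyphenyl on an aromatic carbon. Going by the values given here, no measured step concerns a hydroxyphenyl group, and the single measured step stayed within the scatter with all three numbers near the bottom of the scale. The expected step of a number 2 percentage points higher from compound 3 to compound 4 (within the scatter) is therefore none beyond the scatter. Compound 4 is estimated at 2%, in a range from 0% to 10%.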

Compound 4, a percentage reported as inhibition, at one concentration (the size of the read-out at that concentration, not a potency): 0%
Estimate against measurement, compound 4: 2 percentage points above; measured number inside the range.
By their numbers in this assay, from the lowest: compounds 1, 3, 4 and 2 (each within the scatter of the next).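

In this assay, 3-hydroxyphenyl in place of 2-hydroxyphenyl on this carbon next to the ring nitrogen gives no change at the digits printed from compound 3 to compound 4 (within the scatter). The other varied group tells the same story: furan-2-yl in place of thiophen-3-yl gives a number 4.5 percentage points lower from compound 2 to compound 4 (within the scatter), and furan-2-yl in place of thiophen-2-yl gives no change at the digits printed from compound 1 to compound 4 (within the scatter). So neither change separates these compounds, and nothing available explains these numbers. All four numbers lie near the bottom of the scale. From the compounds shown here alone, whether an aminophenyl or carboxyphenyl group in place of hydroxyphenyl would give a clearly higher number remains open.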